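Paw edema series: triazole thioether oximes, one methoxy removed

The source may hold more compounds than are shown below. What is called first, only, known or untested is meant among the compounds shown, and "the series" means these compounds.

Measured so far:
compound 1 `COc1ccc(-c2nnc(SC/C(=N/O)c3ccccc3)n2-c2ccccc2)cc1` 73%
compound 2 `COc1ccc(-c2nnc(SC/C(=N/O)c3ccccc3)n2-c2ccccc2)cc1OC` 78%
compound 3 `CCn1c(SC/C(=N/O)c2ccccc2)nnc1-c1cc(OC)c(OC)c(OC)c1` 74%

All three were run in a functional assay on the whole organism (strain albino) for inhibition, with Rattus norvegicus as the target, read by paw edema, with a stated time of 5 h, at a dose of 0.28 mmol/kg by the oral route; on this read-out higher numbers stand for more inhibition at the one dose given (going by the name of the read-out) and lower numbers for less inhibition. Compound 2 gives 78%, compound 1 gives 73% and compound 3 gives 74%; the three numbers lie within the usual scatter of one another, so no order among them is claimed.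

One single-point change is measured. Between compound 2 and compound 1 the difference is hydrogen in place of methoxy on an aromatic carbon, and the step is a number 5 percentage points lower from compound 2 to compound 1 (within the scatter).

Compound 3 carries a different core; how its core differs from that of compound 2 is not broken down here.

Compound 4 `CCn1c(SC/C(=N/O)c2ccccc2)nnc1-c1ccc(OC)c(OC)c1` is not yet measured. It differs from compound 3 by hydrogen in place of methoxy on an aromatic carbon. Among the measured compounds shown here, this is the same kind of change as the one from compound 2 to compound 1, not the same: the site in compound 3 is also described as meta to a methoxy group (2 heavy atoms), which the site in compound 2 is not.

The expected step is a number 5 percentage points lower from compound 3 to compound 4 (within the scatter), resting on a number 5 percentage points lower from compound 2 to compound 1 (within the scatter), which stayed within the scatter. Compound 4 is therefore estimated at 69%, between 58% and 80%.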

Compound 4, a percentage reported as inhibition, in the whole organism at one dose (the size of the read-out at that dose, not a potency): 71%
Compound 4: the middle estimate sits 2 percentage points below what was measured; low and high end bracket the measured number.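

In this assay, hydrogen in place of methoxy on an aromatic carbon has now been read on two cores, and the two steps do not differ: the same change on two cores in this assay, a number 5 percentage points lower (within the scatter) from compound 2 to compound 1 and a number 3 percentage points lower (within the scatter) from compound 3 to compound 4, 2 percentage points apart, within the scatter of two such steps

Among the compounds shown here, this shows that the change carries from one core to the other without a detectable difference, although the site in compound 3 is also meta to a methoxy group; it does not show that the methoxy group makes no difference, and with only two steps, each within the scatter, it sets no general rule for the series. Ethyl in place of phenyl on the aromatic nitrogen, a number 7 percentage points lower from compound 2 to compound 4 (within the scatter), also gives no readable difference, alongside a number 3 percentage points lower from compound 3 to compound 4 (within the scatter).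

The compounds shown carry only methoxy groups on that aromatic ring and only ethyl or phenyl on the nitrogen, so an amine or a chlorine on the ring, or a longer chain on the nitrogen, remains open. The oxime is also constant throughout, which leaves a carboxylic acid in its place open too.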